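Swapping 4-methylpiperazin-1-yl for an open chain

This account rests on a few compounds, and the source may have more. Where it says the series, first, only, none or still open, it means among the compounds named here.

Compound 1 `O=C(CCSc1ccc2c(/C=C/c3ccccn3)n[nH]c2c1)Nc1ccc(Cl)c(C(F)(F)F)c1` reads > 10000 nM in an ADME assay on BaF3 cells (Mus musculus) for antiproliferative activity, read by CCK-8 assay, with a stated time of 72 h (on this read-out higher numbers stand for weaker inhibition of growth and lower numbers for stronger inhibition of growth), and that is a limit of the assay, not a number. Among the measured compounds shown here, compound 2 `CN1CCN(Cc2ccc(NC(=O)CCSc3ccc4c(/C=C/c5ccccn5)n[nH]c4c3)cc2C(F)(F)F)CC1` gives 2480 nM in this assay as the only actual number so far. For the measured compounds named here, the one measured step, an at least 4.0-fold lower number from compound 1 to compound 2 (0.60 log units; beyond the scatter), put (4-methylpiperazin-1-yl)methyl in place of chloro on an aromatic carbon. Compound 3 `CN(C)CCN(C)Cc1ccc(NC(=O)CCSc2ccc3c(/C=C/c4ccccn4)n[nH]c3c2)cc1C(F)(F)F` alters that group: (2-(dimethylamino)ethyl)(methyl)amino in place of 4-methylpiperazin-1-yl on a saturated chain carbon bound to an aromatic carbon with (2-(dimethylamino)ethyl)(methyl)amino in place of 4-methylpiperazin-1-yl on a saturated chain carbon bound to an aromatic carbon. The counted features match, so with compound 2 at 2480 nM as the anchor a similar number is expected. The estimated 1.2-fold lower number from compound 2 to compound 3 (0.09 log units; within the scatter) stays within the scatter, with no direction expected. Compound 3 is estimated at 2000 nM with an expected range of 700 nM to 6000 nM in this assay.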

Compound 3, concentration for 50% growth inhibition: 1850 nM
The estimate for compound 3 lay 1.1-fold (0.03 log units) above the measured number; low and high end bracket the measured number.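

In this assay, the open (2-(dimethylamino)ethyl)(methyl)amino chain replaces the 4-methylpiperazin-1-yl ring with a 1.3-fold lower number from compound 2 to compound 3 (0.13 log units; within the scatter), so these two compounds show that the ring can be opened without a change beyond the scatter. The open chain also keeps the gain over chloro, with an at least 5.4-fold lower number from compound 1 to compound 3 (0.73 log units; beyond the scatter). The reading for compound 1 is a limit, so that step gives only a minimum size: the limit of > 10000 nM in this assay, at which 1 of the 3 values shown sits.

From the compounds shown here alone, whether a shorter dimethylamino group or a morpholine ring would read the same remains open. So does whether a primary amine would.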